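From a dimethylamino ether to a chloro ether

A few compounds are considered here, and "the series" means these few. Any claim that something is new, unique, unknown or untested is made for them only; others in the source may bear on it.

Of the compounds shown here, two built on one shared core have been measured in an ADME assay for permeability, using PAMPA, with a stated time of 30 min, at pH 7.4; a lower number here means that the compound crosses the layer more slowly, a higher number that the compound crosses the layer faster. Compound 1, `COc1cccc(CNCCCNc2ccnc3cc(-c4ccc(F)cc4)ccc23)c1O`, gives 237 10^-6 cm/s in this assay. Compound 2, `CN(C)c1cccc(Oc2ccc3c(NCCCNCc4ccco4)ccnc3c2)c1`, gives 317 10^-6 cm/s in this assay, the higher of the two numbers; its gap to compound 1 lies within the usual scatter, so the two compounds cannot be ordered on this count. Compound 3, `Clc1ccc(Oc2ccc3c(NCCCNCc4ccco4)ccnc3c2)cc1`, has not yet been measured in this assay. It differs from compound 2 in one place: 4-chlorophenyl in place of 3-(dimethylamino)phenyl on an oxygen on an aromatic ring. Among the measured compounds shown here, no pair of measured compounds differs by this single change, so there is no measured step to lean on, and the expectation rests on compound 2 alone. Given that compound 2 gives 317 10^-6 cm/s, the expected step is a 1.1-fold lower number from compound 2 to compound 3 (0.02 log units; within the scatter), none beyond the scatter in either direction. Compound 3 is therefore estimated at 300 10^-6 cm/s in this assay, with a range from 170 10^-6 cm/s to 520 10^-6 cm/s.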

Compound 3, apparent permeability: 317 10^-6 cm/s
Compound 3: middle estimate off by 1.1-fold (0.02 log units), on the low side; the range from low to high includes it.
By their numbers in this assay, from the lowest: compounds 1, 2 and 3 (each within the scatter of the next).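

In this assay, among the compounds shown here, replacing 3-(dimethylamino)phenyl with 4-chlorophenyl on an oxygen on an aromatic ring gives no change at the digits printed from compound 2 to compound 3 (within the scatter), the first single-place step. At this position, then, a dimethylamino group at the 3-position of the phenyl ring and a chlorine at the 4-position give values that this read-out cannot tell apart, even though the exchange also takes away the hydrogen-bond acceptor counted on the leaving group and reduces the heavy atoms from nine to seven. No measurement is available that explains this lack of separation, so the result stands as an observation only.

This is one step between two substituted phenyl ethers, and because the substituent and its place on the ring change together, the step cannot show what either change does alone. It also leaves open whether the same position would stay within the scatter with a carboxylic acid or a primary amine on that phenyl ring, or with a longer chain between the ring and the oxygen.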